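The source may hold more compounds than are shown below. What is called first, only, known or untested is meant among the compounds shown, and "the series" means these compounds.

Measured so far:
Compound 1, `CCC(=O)Nc1ccc(N2CCN(c3ccc(OC[C@@H]4CO[C@@](Cn5cncn5)(c5ccc(Cl)cc5Cl)O4)cc3)CC2)cc1`: 5460 nM
Compound 2, `O=C(CCc1ccccc1)Nc1ccc(N2CCN(c3ccc(OC[C@@H]4CO[C@@](Cn5cncn5)(c5ccc(Cl)cc5Cl)O4)cc3)CC2)cc1`: 5340 nM

In a functional assay on HepG2 cells (Homo sapiens) for inhibition, read by MTT assay, with a stated time of 48 h (a lower number here means a stronger inhibitor, a higher number a weaker inhibitor), compound 1 gives 5460 nM and compound 2 gives 5340 nM. Within the data shown here, compound 2 has the lowest of the two numbers, but the only step so far, a 1.0-fold lower number from compound 1 to compound 2 (0.01 log units; within the scatter), is within the scatter, so the two compounds cannot be told apart on these data.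

Compound 3, `Cc1ccc(C(=O)Nc2ccc(N3CCN(c4ccc(OC[C@@H]5CO[C@@](Cn6cncn6)(c6ccc(Cl)cc6Cl)O5)cc4)CC3)cc2)o1`, has not yet been measured. It differs from compound 2 in one place: 5-methylfuran-2-yl in place of phenethyl on a carbonyl carbon. Among the measured compounds shown here, the one measured step, a 1.0-fold lower number from compound 1 to compound 2 (0.01 log units; within the scatter), bears directly on this, since it also changed the group on the carbonyl carbon next to the amide-type nitrogen and left the number essentially unchanged. On that basis the step of a 1.0-fold lower number from compound 2 to compound 3 (0.01 log units; within the scatter) is expected to stay within the scatter, with no clear direction. Compound 3 is therefore estimated at 5200 nM, with a range from 2000 nM to 14000 nM.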

Compound 3, half-maximal inhibitory concentration: 8700 nM
Beside the measured number, compound 3's estimate is 1.7-fold (0.22 log units) below it, within the range that was stated.
By their numbers in this assay, from the lowest: compounds 2, 1 and 3 (each within the scatter of the next).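

In this assay, putting 5-methylfuran-2-yl in place of phenethyl on the carbonyl carbon gives a 1.6-fold higher number from compound 2 to compound 3 (0.21 log units; within the scatter) and putting it in place of ethyl gives a 1.6-fold higher number from compound 1 to compound 3 (0.20 log units; within the scatter) as well. Until now this position had carried only open chains, ethyl and phenethyl, whereas here a five-membered aromatic ring with one hetero atom sits directly on the carbonyl carbon, and both steps still lie within the scatter, so the three compounds cannot be told apart. No measurement here offers an explanation for these numbers.

Open, on these data alone, is whether an amine or a carboxylic acid on this carbonyl carbon would give a step beyond the scatter. Also open, as far as these compounds go, is whether furan-2-yl without its methyl would read the same as 5-methylfuran-2-yl.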